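Carboxy to (Morpholin-4-yl)carbonyl: an Expected Step

The source may hold more compounds than are shown below. What is called first, only, known or untested is meant among the compounds shown, and "the series" means these compounds.

Measured compounds:
compound 1, `O=C(O)/C=C/c1ccncc1-c1ccc2cc[nH]c2c1`, 2.4 nM
compound 2, `CC(C)[C@@H](NC(=O)/C=C/c1ccncc1-c1ccc2ccccc2c1)C(=O)O`, "not determined" (no result reported)

For the measured compounds named here, in an assay on a protein complex for inhibition of CDK8/Cyclin C (Homo sapiens), with a stated time of 1 h (on this read-out higher numbers stand for weaker inhibition and lower numbers for stronger inhibition), compound 1 gives 2.4 nM, and this is the only number in the set. Compound 2 carries the same double-bonded chain and a related amide, but in this assay compound 2 gives "not determined" (no result reported), so nothing about amides in this series can be read from it.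

Compound 3, `O=C(/C=C/c1ccncc1-c1ccc2cc[nH]c2c1)N1CCOCC1`, is not yet measured. It differs from compound 1 by morpholin-4-yl in place of hydroxy on a carbonyl carbon, so that a carboxy becomes a (morpholin-4-yl)carbonyl. Going by the values given here, no measured pair in the set shows what such a change does here, and the one amide that exists, compound 2, has no value to lean on.

Given that, a step in the direction of weaker inhibition is expected, of moderate size, and it is estimated that a 6.3-fold higher number from compound 1 to compound 3 (0.80 log units; beyond the scatter). In this assay compound 3 is expected to give about 15 nM, with a range from 3 nM to 80 nM.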

Compound 3, half-maximal inhibitory concentration: 43.9 nM
Compound 3: the middle estimate sits 2.9-fold (0.47 log units) below what was measured; the measured number falls inside the stated range.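

In this assay the carbonyl carbon on the double-bonded chain now shows its first measurable change: the step to morpholin-4-yl in place of hydroxy is large, an 18-fold higher number from compound 1 to compound 3 (1.26 log units; beyond the scatter), and this is something compound 2 could not show without a value. Even so, compound 3 gives 43.9 nM, so within this pair a number in the nanomolar range survives the loss of the carboxy, and the free acid is not an absolute requirement for inhibition on this read-out. Nothing at hand explains the size of the step, which therefore stands as an observation alone.

With a single amide carrying a value, the compounds shown leave open whether this loss belongs to amides at this carbonyl in general or to morpholin-4-yl in particular. As far as these compounds go, a piperidin-1-yl, with carbon in place of the ring oxygen, a dimethylamino on the same carbonyl, or a methyl ester of compound 1 would each help to separate those readings, and how much of the step depends on the shared core also remains unknown.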